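Ring Size at the Basic Amine of a Receptor Antagonist

The compounds below may be only part of what the source reports. "The series", "measured", "known", "first", "only" and "open" are said of these compounds alone.

Compound 1 `CCCCN(CCCN1CCCCC1)c1cc(-c2ccccc2)no1`: > 40000 nM
Compound 2 `c1ccc(-c2cc(N(CCCN3CCCCC3)Cc3cccc4ccccc34)on2)cc1`: 500 nM
Compound 3 `c1ccc(-c2cc(N(CCCN3CCCCC3)Cc3ccc4ccccc4c3)on2)cc1`: 2000 nM

In a functional assay for antagonist activity at proteinase-activated receptor 1 (Homo sapiens) (a higher number here means a weaker inhibitor, a lower number a stronger inhibitor), compound 1 reports only a limit, > 40000 nM. Compound 2 holds the lowest of the two numbers, set apart from compound 3 by a 4.0-fold higher number from compound 2 to compound 3 (0.60 log units; beyond the scatter). The unmeasured compound 4 `c1ccc(-c2cc(N(CCN3CCCCCC3)Cc3cccc4ccccc34)on2)cc1` differs from compound 2 by azepan-1-yl in place of (piperidin-1-yl)methyl on a saturated chain carbon, two bonds along the chain from a nitrogen on an aromatic ring. Among the measured compounds shown here, none of the measured steps touches this part of the molecule: an at least 80-fold lower number from compound 1 to compound 2 (1.90 log units; beyond the scatter) and an at least 20-fold lower number from compound 1 to compound 3 (1.30 log units; beyond the scatter) both concern the group on the other arm of the aromatic nitrogen. For the measured compounds named here, with no measured step bearing on the change, compound 4 is expected to show no step beyond the scatter, a 1.4-fold higher number from compound 2 to compound 4 (0.15 log units; within the scatter). Compound 4 is therefore estimated at 700 nM, between 200 nM and 2500 nM.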

Compound 4, half-maximal inhibitory concentration: 5000 nM
Estimate against measurement, compound 4: 7.1-fold (0.85 log units) below; measured number outside the range, above it.
By their numbers in this assay, from the lowest: compound 2; then compound 3; then compound 4. At a limit, above all of these: compound 1.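

In this assay, the arm carrying the saturated ring matters: replacing 3-(piperidin-1-yl)propyl with 2-(azepan-1-yl)ethyl gives a 10-fold higher number from compound 2 to compound 4 (1.00 log units; beyond the scatter), although the two compounds have the same atoms, joined differently. The earlier steps shown here changed only the other arm of the aromatic nitrogen, so they could not show that this arm also moves the number. Nothing shown gives a reason for this step.

Ring size and chain length change together here, so it remains open which of them accounts for the step. A 2-(piperidin-1-yl)ethyl or 3-(azepan-1-yl)propyl arm on the core of compound 2 would separate the two.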